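This account rests on a few compounds, and the source may have more. Where it says the series, first, only, none or still open, it means among the compounds named here.

So far, two compounds built on a shared core have numbers in a functional assay on HCT-8 cells (Homo sapiens) for cytotoxicity; a lower number here means that less compound is needed, a higher number that more compound is needed for the effect. Compound 1 `COC1=C(C)C(=O)/C(=C(O)/C=C/c2ccc(F)cc2)C(=O)C1(C)C` gives 3.6 ug/mL, while compound 2 `COC1=C(C)C(=O)/C(=C(O)/C=C/c2c(C)cc(C)cc2C)C(=O)C1(C)C` gives 8.4 ug/mL. The gap between them lies beyond the usual scatter, so compound 1 holds the lower of the two numbers, and less of it is needed for the effect.

Compound 3 `COC1=C(C)C(=O)/C(=C(O)/C=C/c2cccs2)C(=O)C1(C)C` has not yet been measured. It carries thiophen-2-yl in place of 4-fluorophenyl on a double-bonded chain carbon bound to a double-bonded chain carbon. Among the compounds with values here, no measured pair shows this exchange on its own, so the starting point is compound 1 at 3.6 ug/mL. In this assay, from the compounds shown here alone, no step beyond the scatter is expected, and the direction remains open. The estimated change is a 1.3-fold higher number from compound 1 to compound 3 (0.10 log units; within the scatter). For compound 3 the expected value is 4.5 ug/mL, within an estimated range of 1.8 ug/mL to 11 ug/mL.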

Compound 3, concentration for half-maximal effect: 8.6 ug/mL
Compound 3: middle estimate off by 1.9-fold (0.28 log units), on the low side; low and high end bracket the measured number.
By their numbers in this assay, from the lowest: compound 1; then compounds 2 and 3 (each within the scatter of the next).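

Within the data shown here, this is the first exchange at this position that can be read on its own: in this assay, putting thiophen-2-yl in place of 4-fluorophenyl gives a 2.4-fold higher number from compound 1 to compound 3 (0.38 log units; beyond the scatter) and so takes more compound to reach the effect. The group on a double-bonded chain carbon bound to a double-bonded chain carbon therefore matters to this number, and among the three compounds, compound 1 keeps the lowest value. No measurement at hand bears on the reason for this shift.

The exchange alters the ring size, brings in sulfur and removes fluorine all at once, so this single step cannot show which of these changes counts. Plain phenyl, 4-chlorophenyl or a phenyl ring carrying an amine at this position would help to separate them, and how each would read remains open.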